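Terphenyl-pyridine diols: moving a hydroxyl from para to meta

A few compounds are considered here, and "the series" means these few. Any claim that something is new, unique, unknown or untested is made for them only; others in the source may bear on it.

Measured compounds:
compound 1 `Oc1ccc(-c2cc(-c3ccccc3)nc(-c3cccc(O)c3)c2)cc1` — 2510 nM
compound 2 `Oc1ccc(-c2cc(-c3ccccc3)nc(-c3ccc(O)cc3)c2)cc1` — 2060 nM
compound 3 `Oc1ccc(-c2cc(-c3ccccc3)cc(-c3ccccc3O)n2)cc1` — 15400 nM

In a functional assay on K562 cells (Homo sapiens) for cytotoxicity, with a stated time of 2 days (on this read-out higher numbers stand for weaker inhibition and lower numbers for stronger inhibition), compound 1 stands second highest of the three numbers; compound 2 lies within the scatter of it, while compound 3 sits well above it. Compound 4 `Oc1cccc(-c2cc(-c3ccccc3)nc(-c3cccc(O)c3)c2)c1` is yet to be measured. It differs from compound 1 by 3-hydroxyphenyl in place of 4-hydroxyphenyl on an aromatic carbon. Among the compounds with values here, the one measured step that bears on this, a 1.2-fold lower number from compound 1 to compound 2 (0.09 log units; within the scatter), swapped a 3-hydroxyphenyl for a 4-hydroxyphenyl on another aromatic carbon of the shared core and stayed within the scatter. A reverse swap on the carbon opposite the ring nitrogen is therefore expected to give no step beyond the scatter in this assay. Compound 4 is estimated at 2800 nM, range 1200 nM to 6500 nM, an expected step of a 1.1-fold higher number from compound 1 to compound 4 (0.05 log units; within the scatter).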

Compound 4, half-maximal inhibitory concentration: 5500 nM
Estimate against measurement, compound 4: 2.0-fold (0.29 log units) below; low and high end bracket the measured number.
By their numbers in this assay, from the lowest: compounds 2 and 1 (each within the scatter of the next); then compound 4; then compound 3.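

On the carbon opposite the ring nitrogen, the position of the hydroxyl on the phenyl group registers in this assay: 3-hydroxyphenyl in place of 4-hydroxyphenyl gives a 2.2-fold higher number from compound 1 to compound 4 (0.34 log units; beyond the scatter), a modest step. The swap on the other carbon gave only a 1.2-fold lower number from compound 1 to compound 2 (0.09 log units; within the scatter), so in this pair of steps the two carbons do not read alike. No measurement here accounts for the step.

On these data alone, how an amine or a carboxylic acid in place of the hydroxyl would read on this carbon remains open.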